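A few compounds are considered here, and "the series" means these few. Any claim that something is new, unique, unknown or untested is made for them only; others in the source may bear on it.

The three measured compounds share one core and differ at its outer groups. Compound 1 `COc1cc(Cn2cc(CNC(=O)c3cn(-c4ccccc4)nc3-c3ccccc3)nn2)cc(OC)c1OC` gives 1000 nM in a functional assay on MIA PaCa-2 cells (Homo sapiens) for antiproliferative activity, read by sulforhodamine B assay, with a stated time of 48 h; a lower number here means a stronger inhibitor of growth, a higher number a weaker inhibitor of growth. Compound 2 `O=C(NCc1cn(Cc2ccc(C(F)(F)F)cc2)nn1)c1cn(-c2ccccc2)nc1-c1ccc(Cl)cc1` gives 1100 nM in this assay. Compound 3 `COc1ccc(Cn2cc(CNC(=O)c3cn(-c4ccccc4)nc3-c3ccc(Cl)cc3)nn2)cc1OC` gives 9400 nM in this assay, the highest of the three numbers and so the weakest growth inhibitor measured here. Within the data shown here, the single measured step that changes only one place is an 8.5-fold higher number from compound 2 to compound 3 (0.93 log units; beyond the scatter), which exchanges the group on a saturated chain carbon bound to an aromatic nitrogen.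

Compound 4 `COc1cc(Cn2cc(CNC(=O)c3cn(-c4ccccc4)nc3-c3ccc(Cl)cc3)nn2)cc(OC)c1OC` has not been measured. It differs from compound 3 by methoxy in place of hydrogen on an aromatic carbon. Among the measured compounds shown here, no measured step tests this methoxy addition on its own. Compound 1, which also carries a 3,4,5-trimethoxyphenyl group but differs elsewhere as well, gives 1000 nM, a clearly lower number than compound 3 with its 9400 nM. The expectation is therefore a moderate move toward a lower number, an expected step of a 3.8-fold lower number from compound 3 to compound 4 (0.58 log units; beyond the scatter). Compound 4 is estimated at 2500 nM, with a likely range from 700 nM to 9000 nM.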

Compound 4, concentration for 50% growth inhibition: 3500 nM
The estimate for compound 4 lay 1.4-fold (0.15 log units) below the measured number, and the stated range covers the measured number.
By their numbers in this assay, from the lowest: compounds 1 and 2 (each within the scatter of the next); then compound 4; then compound 3.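

In this assay the added methoxy alone gives a 2.7-fold lower number from compound 3 to compound 4 (0.43 log units; beyond the scatter) and so, with all else fixed, lowers the number on this aromatic ring. The gain is partial, since the 3,4,5-trimethoxyphenyl group still compares poorly with 4-(trifluoromethyl)phenyl in a 3.2-fold higher number from compound 2 to compound 4 (0.50 log units; beyond the scatter) while the rest of the molecule stays the same. Among these compounds, the compounds also give a first isolated reading of chloro in place of hydrogen on an aromatic carbon, which with the 3,4,5-trimethoxyphenyl group held constant gives a 3.5-fold higher number from compound 1 to compound 4 (0.54 log units; beyond the scatter) and so raises the number.

No measurement at hand explains why any of these steps runs in its direction. Also open, as far as these compounds go, is how a hydroxy group or an amine on the same aromatic carbon would compare with the methoxy.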